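The source may hold more compounds than are shown below. What is called first, only, known or untested is meant among the compounds shown, and "the series" means these compounds.

In an assay on HEK293 cells for agonist activity at transient receptor potential cation channel subfamily M member 8 (Homo sapiens), read by fluorescence and calcium flux, with a stated time of 15 min (on this read-out lower numbers stand for an effect already at smaller amounts and higher numbers for an effect only at larger amounts of compound), compound 3 `CCN(Cc1cccs1)C(=O)COc1ccccc1` gives 1400 nM, the higher of the two numbers reported so far. Compound 1 `Cc1ccc(OCC(=O)N(Cc2cccs2)C(C)C)cc1` gives 70 nM in this assay, and compound 2 `CCN(Cc1cn[nH]c1)C(=O)COc1ccc(C)cc1` is reported in this assay as "active" (no number reported) without a number. Compound 4 `CCN(Cc1cccs1)C(=O)COc1ccc(C)cc1` has not yet been measured. It differs from compound 3 in one place: methyl in place of hydrogen on an aromatic carbon. Compound 1 also carries a methyl on a six-membered aromatic ring of carbon only, though it differs from compound 4 elsewhere as well, so the number for compound 1, 70 nM, only hints that the methyl may go with a smaller number. The step from compound 3 to compound 4 is expected to be a 4.7-fold lower number from compound 3 to compound 4 (0.67 log units; beyond the scatter), toward a smaller number and beyond the scatter. Compound 4 is therefore estimated at 300 nM, within a range from 80 nM to 1500 nM.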

Compound 4, half-maximal effective concentration: 8 nM
Compound 4: middle estimate off by 38-fold (1.57 log units), on the high side; the whole stated range lies above it.
By their numbers in this assay, from the lowest: compound 4; then compound 1; then compound 3.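

Putting a methyl in place of hydrogen on an aromatic carbon of the six-membered ring, para to a large group, gives a 180-fold lower number from compound 3 to compound 4 (2.24 log units; beyond the scatter) and so shows that this single position matters greatly. Hydrogen in place of methyl on the saturated chain carbon bound to the amide-type nitrogen gives an 8.8-fold lower number from compound 1 to compound 4 (0.94 log units; beyond the scatter) and is a modest step by comparison. No measurement shown accounts for either step. Going by these compounds, whether an ethyl group, a chlorine or a methoxy group at this same ring position would serve as well as methyl remains open.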